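From phenyl to 4-nitrophenyl: a small step expected

The source may hold more compounds than are shown below. What is called first, only, known or untested is meant among the compounds shown, and "the series" means these compounds.

In a functional assay on A549 cells (Homo sapiens) for antiproliferative activity, read by MTT assay, with a stated time of 48 h (a higher number here means a weaker inhibitor, a lower number a stronger inhibitor), compound 1 (`Oc1ccc2ccccc2c1C(Nc1nc2ccc(Cl)cc2s1)c1cn(-c2ccccc2)nc1-c1cccc(Cl)c1`) gives 33300 nM and compound 2 (`Oc1ccc2ccccc2c1C(Nc1nc2ccc(Cl)cc2s1)c1cn(-c2ccccc2)nc1-c1ccccc1`) gives 51100 nM as its value, so these two numbers lie within the scatter of each other. Compound 3 (`O=[N+]([O-])c1ccc(-c2nn(-c3ccccc3)cc2C(Nc2nc3ccc(Cl)cc3s2)c2c(O)ccc3ccccc23)cc1`) differs from compound 2 by nitro in place of hydrogen on an aromatic carbon, para to a large group (nitro in place of hydrogen on an aromatic carbon), which also reads as phenyl to 4-nitrophenyl. Among the measured compounds shown here, the only measured step puts hydrogen in place of chloro on an aromatic carbon and shows a 1.5-fold higher number from compound 1 to compound 2 (0.19 log units; within the scatter) as its size. For the measured compounds named here, that is a different change, and no measured compound carries nitro, so it guides only weakly. No step beyond the scatter is therefore expected in this assay here, in either direction. The expected change is a 1.3-fold lower number from compound 2 to compound 3 (0.11 log units; within the scatter) by this estimate. Compound 3 is estimated at 40000 nM (from 13000 nM to 100000 nM).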

Compound 3, half-maximal inhibitory concentration: 57200 nM
Beside the measured number, compound 3's estimate is 1.4-fold (0.16 log units) below it; measured number inside the range.
By their numbers in this assay, from the lowest: compounds 1, 2 and 3 (each within the scatter of the next).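

In this assay, nitro in place of hydrogen on an aromatic carbon, para to a large group, gives a 1.1-fold higher number from compound 2 to compound 3 (0.05 log units; within the scatter), so a group of three heavy atoms at this place produces no readable difference. Putting 4-nitrophenyl in place of 3-chlorophenyl gives a 1.7-fold higher number from compound 1 to compound 3 (0.23 log units; within the scatter), which is also within the scatter, so phenyl, 3-chlorophenyl and 4-nitrophenyl cannot be told apart in this assay. Nothing available explains this result.

On these data alone, it remains open whether an amine or a carboxylic acid at this same place would give a step beyond the scatter, and whether nitro elsewhere on this six-membered ring would do so. As far as these compounds go, it is also open whether changes to other parts of the shared core would shift the number more than these have.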